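Aryl variation on the ring nitrogen: cytotoxicity notes

This account rests on a few compounds, and the source may have more. Where it says the series, first, only, none or still open, it means among the compounds named here.

The three measured compounds share one core and differ only in the aryl group attached to the aromatic nitrogen: compound 1 `C/C(=C\CC/C(C)=C/CC[C@@H]1[C@@]2(C)CCC(=O)C(C)(C)[C@H]2CC[C@@]1(C)O)CC/C=C(\C)C(=O)OCc1cn(-c2ccc(C(F)(F)F)cc2)nn1`, compound 2 `C/C(=C\CC/C(C)=C/CC[C@@H]1[C@@]2(C)CCC(=O)C(C)(C)[C@H]2CC[C@@]1(C)O)CC/C=C(\C)C(=O)OCc1cn(-c2ccc([N+](=O)[O-])cc2)nn1` and compound 3 `C/C(=C\CC/C(C)=C/CC[C@@H]1[C@@]2(C)CCC(=O)C(C)(C)[C@H]2CC[C@@]1(C)O)CC/C=C(\C)C(=O)OCc1cn(-c2ccc(F)c(Cl)c2)nn1`. In an ADME assay on L132 cells (Homo sapiens) for cytotoxicity, read by MTT assay, with a stated time of 48 h (a higher number here means a weaker inhibitor, a lower number a stronger inhibitor), compound 1 gives only a limit of the assay, > 150000 nM. Compound 2 in this assay likewise gives a limit, > 150000 nM. Compound 3 in this assay also gives a limit, > 150000 nM. The steps a step that the two limits leave unreadable from compound 1 to compound 2, a step that the two limits leave unreadable from compound 1 to compound 3 and a step that the two limits leave unreadable from compound 2 to compound 3 are therefore unreadable because every value shown sits at the limit of > 150000 nM in this assay, at which 3 of the 3 values shown sit. Compound 3 thus stands nowhere distinguishable from its two neighbours; it is at the limit, as they are.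

Compound 4 `C/C(=C\CC/C(C)=C/CC[C@@H]1[C@@]2(C)CCC(=O)C(C)(C)[C@H]2CC[C@@]1(C)O)CC/C=C(\C)C(=O)OCc1cn(-c2ccc(Br)cc2)nn1` is the next member. It differs from compound 3 by 4-bromophenyl in place of 3-chloro-4-fluorophenyl on an aromatic nitrogen. Among the measured compounds shown here, the steps that bear on this change are the three above, each of unknown size, and none of them shows any aryl swap on the aromatic nitrogen moving a value off the limit. The expectation is therefore that compound 4 in this assay remains at the limit as well, with the estimated step that the limit leaves unreadable from compound 3 to compound 4 meaning no move beyond the scatter. For compound 4 the estimate in this assay is 200000 nM, with a range from 100000 nM to 400000 nM.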

Compound 4, half-maximal inhibitory concentration: > 150000 nM
Compound 4 gave a limit, no number (the forecaster's own chance of this, stated with the estimate: 85%); the middle value lies beyond the limit too.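

In this assay no step from compound 1, compound 2 or compound 3 to compound 4 can be read, because every value shown is a limit of the assay and not a number: the limit of > 150000 nM in this assay, at which 4 of the 4 values shown sit.

The compounds shown leave open whether any aryl group on the aromatic nitrogen of the shared core would bring a value off this limit.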